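Arylcyclopropane amides: para-substituent swap on the distal phenyl

The source may hold more compounds than are shown below. What is called first, only, known or untested is meant among the compounds shown, and "the series" means these compounds.

Measured compounds:
compound 1 `CC[C@H](C)[C@H](N)CN(C(=O)[C@@H]1C[C@H]1c1ccccc1)c1ccc(-c2ccc(C(C)(C)C)cc2)cc1`: a functional assay for agonist activity at G protein-coupled receptor 88 (Homo sapiens), read by HTRF and cAMP accumulation (on this read-out lower numbers stand for an effect already at smaller amounts and higher numbers for an effect only at larger amounts of compound), 750 nM
compound 2 `CC[C@H](C)[C@H](N)CN(C(=O)[C@@H]1C[C@H]1c1ccccc1)c1ccc(-c2ccc(CO)cc2)cc1`: 1100 nM
compound 3 `CC[C@H](C)[C@H](N)CN(C(=O)[C@@H]1C[C@H]1c1ccccc1)c1ccc(-c2ccc(NC(C)=O)cc2)cc1`: 5500 nM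

Compound 3 stands highest of the three numbers in this assay. The step to compound 4 `CC[C@H](C)[C@H](N)CN(C(=O)[C@@H]1C[C@H]1c1ccccc1)c1ccc(-c2ccc(CNC)cc2)cc1` is (methylamino)methyl in place of acetamido on an aromatic carbon. The bearing steps are a 7.3-fold higher number from compound 1 to compound 3 (0.87 log units; beyond the scatter) and a 5.0-fold higher number from compound 2 to compound 3 (0.70 log units; beyond the scatter), both modest and beyond the scatter, while a 1.5-fold higher number from compound 1 to compound 2 (0.17 log units; within the scatter) stays within it. Acetamido is thus the one group at this place tied to a clearly higher number, and replacing it is expected to move back toward compounds 1 and 2. For compound 4 the expected step is a 3.7-fold lower number from compound 3 to compound 4 (0.56 log units; beyond the scatter). Compound 4 is estimated at 1500 nM, within 400 nM to 6000 nM.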

Compound 4, half-maximal effective concentration: 6400 nM
The estimate for compound 4 lay 4.3-fold (0.63 log units) below the measured number, outside the stated range (above it).
By their numbers in this assay, from the lowest: compounds 1 and 2 (each within the scatter of the next); then compounds 3 and 4 (each within the scatter of the next).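

In this assay, among these compounds, putting (methylamino)methyl in place of acetamido gives a 1.2-fold higher number from compound 3 to compound 4 (0.07 log units; within the scatter), so the two groups are not separated and acetamido is no longer the only group at this place tied to a clearly higher number. The same group stands apart from the other two, with a 5.8-fold higher number from compound 2 to compound 4 (0.76 log units; beyond the scatter) and an 8.5-fold higher number from compound 1 to compound 4 (0.93 log units; beyond the scatter), which divides the four compounds into two pairs: compounds 1 and 2, and compounds 3 and 4. Nothing available explains this division.

From the compounds shown here alone, it remains open whether a carboxylic acid, a plain aminomethyl or a dimethylaminomethyl at this place would fall with compounds 1 and 2 or with compounds 3 and 4.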